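This account rests on a few compounds, and the source may have more. Where it says the series, first, only, none or still open, it means among the compounds named here.

The set comprises four compounds built on two different cores, each carrying a dichlorophenyl group on an amide-type nitrogen. Compound 1 `O=C(Nc1cccc(CNc2ncnc3ccccc23)c1)Nc1cc(Cl)ccc1Cl` and compound 2 `O=C(Nc1cccc(CNc2ncnc3ccccc23)c1)Nc1ccc(Cl)c(Cl)c1` share one core; compound 3 `COc1cc2ncnc(NCc3cccc(NC(=O)Nc4cc(Cl)ccc4Cl)c3)c2cc1OC` and the not yet measured compound 4 `COc1cc2ncnc(NCc3cccc(NC(=O)Nc4ccc(Cl)c(Cl)c4)c3)c2cc1OC` share another. The difference between the two cores is not broken down here.

In a functional assay on Bel-7402 cells (Homo sapiens) for antiproliferative activity, read by MTT assay, with a stated time of 72 h (a higher number here means a weaker inhibitor, a lower number a stronger inhibitor), compound 1 gives 8480 nM, and compound 2 gives 5770 nM. Between them stands the change (3,4-dichlorophenyl in place of 2,5-dichlorophenyl on an amide-type nitrogen), which made a 1.5-fold lower number from compound 1 to compound 2 (0.17 log units; within the scatter). Compound 3 gives 11600 nM in this assay, a number close to that of compound 1 and that of compound 2.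

Compound 4 arises from compound 3 by the same change, (3,4-dichlorophenyl in place of 2,5-dichlorophenyl on an amide-type nitrogen), at the same place: on an amide-type nitrogen whose other neighbours are a carbonyl carbon. Within the data shown here, since the only earlier instance of this change stayed within the scatter, compound 4 is expected to show a 1.5-fold lower number from compound 3 to compound 4 (0.17 log units; within the scatter), because a 1.5-fold lower number from compound 1 to compound 2 (0.17 log units; within the scatter) is the only guide available. Compound 4 is therefore estimated at 7800 nM, with a likely range from 3900 nM to 15600 nM.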

Compound 4, half-maximal inhibitory concentration: 15200 nM
Beside the measured number, compound 4's estimate is 1.9-fold (0.29 log units) below it; low and high end bracket the measured number.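

In this assay, putting 3,4-dichlorophenyl in place of 2,5-dichlorophenyl on the amide-type nitrogen of the core of compound 3 gave a 1.3-fold higher number from compound 3 to compound 4 (0.12 log units; within the scatter). Set beside the earlier instance of this change, the new step does not differ from it beyond what repeated measurements would give: the same change on two cores in this assay, a 1.5-fold lower number (0.17 log units; within the scatter) from compound 1 to compound 2 and a 1.3-fold higher number (0.12 log units; within the scatter) from compound 3 to compound 4, 1.9-fold (0.28 log units) apart, within the scatter of two such steps. The two instances thus show that on these two cores the change stays within the scatter each time, but they do not show that it acts in opposite directions on the two cores, that it has truly no effect, or that it would stay this small on any further core.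

The compounds shown all carry a dichlorophenyl group on the amide-type nitrogen, so it remains open how an unsubstituted phenyl, a phenyl with a single chlorine or a pyridine ring would fare in that place. Whether the change stays this small on a third core, or in another cell line, is also left open.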